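The source may report more compounds than this note shows. Statements on the series, on what has been measured and on what is new or still open speak of the compounds shown alone.

In a functional assay on HepG2 cells (Homo sapiens) for antiproliferative activity, read by MTT assay, with a stated time of 72 h (a higher number here means a weaker inhibitor, a lower number a stronger inhibitor), compound 3 `CCN(CC)CCn1cccc1/C=N/NC(=O)Nc1ccc(Oc2ccnc3[nH]ccc23)cc1` gives 5880 nM and lies within the scatter of compound 2 `O=C(N/N=C/c1cc(Br)c(O)c(Br)c1)Nc1ccc(Oc2ccnc3[nH]ccc23)c(F)c1` at 6520 nM while being a weaker inhibitor than compound 1 `O=C(N/N=C/c1ccc(O)c(Br)c1)Nc1ccc(Oc2ccnc3[nH]ccc23)c(F)c1` at 1360 nM on this scale. Compound 4 `CN1CCN(CCCn2cccc2/C=N/NC(=O)Nc2ccc(Oc3ccnc4[nH]ccc34)cc2)CC1` differs from compound 3 in one place: (4-methylpiperazin-1-yl)methyl in place of diethylamino on a saturated chain carbon, two bonds along the chain from an aromatic nitrogen (that is, (4-methylpiperazin-1-yl)methyl in place of diethylamino on a saturated chain carbon, two bonds along the chain from an aromatic nitrogen). For the measured compounds named here, the only measured step, bromo in place of hydrogen on an aromatic carbon, gave a 4.8-fold higher number from compound 1 to compound 2 (0.68 log units; beyond the scatter) and is a different change, so it shows only how large one change can be. No step beyond the scatter is therefore expected in this assay for this new change. Compound 4 is expected at 5000 nM within an estimated range from 1800 nM to 14000 nM in this measurement. This estimate means a 1.2-fold lower number from compound 3 to compound 4 (0.07 log units; within the scatter) as the expected step.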

Compound 4, half-maximal inhibitory concentration: 2760 nM
For compound 4 the middle estimate is 1.8-fold (0.26 log units) above the measured one; measured number inside the range.
By their numbers in this assay, from the lowest: compound 1; then compound 4; then compounds 3 and 2 (each within the scatter of the next).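

The chain end, on a saturated chain carbon, two bonds along the chain from an aromatic nitrogen, responds to what it carries: in this assay, the change gives a 2.1-fold lower number from compound 3 to compound 4 (0.33 log units; beyond the scatter), a modest gain. A group with a six-membered non-aromatic ring is therefore accepted at this position, at least in this cell assay. No measured evidence explains this step.

The ring and the chain length change together here, so their contributions cannot be separated. A 3-(diethylamino)propyl group or a 2-(4-methylpiperazin-1-yl)ethyl group would tell them apart.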